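Hydroxy Exchanged for Methyl on an Iminosugar Core

A few compounds are considered here, and "the series" means these few. Any claim that something is new, unique, unknown or untested is made for them only; others in the source may bear on it.

Compound 1, with the structure `CC[C@H]1N[C@@H](CO)[C@@H](O)[C@H](O)[C@H]1O`, was tested in an assay for inhibition of beta-glucuronidase (Bos taurus), tested at 1000 uM (a lower number here means less inhibition, a higher number more inhibition at the concentration tested (going by the name of the read-out)), where compound 1 gives 0%. This is the lowest of the two numbers that have been obtained, and the nearest neighbour is compound 3, of structure `CC[C@@H]1NC[C@@H](O)[C@@H](O)[C@H](O)[C@H]1O`, for which compound 3 gives 0.1% in this assay, a reading that lies within the scatter of compound 1. Compound 2, with the structure `CCC[C@@H]1NC[C@@H](O)[C@@H](O)[C@H](O)[C@H]1O`, was also prepared, but in this assay compound 2 gives "not determined" (no result reported), which is to say that no result was reported for it.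

The account now turns from compound 1 to compound 4, whose structure is `CC[C@@H]1N[C@H](CC)[C@H](O)[C@@H](O)[C@@H]1O`. The change between them is counted as methyl in place of hydroxy on a saturated chain carbon bound to a saturated ring carbon. Cut one bond further out, the same difference reads hydroxymethyl to ethyl.

Among the measured compounds shown here, no pair of measured compounds shows this exchange, so no measured step can be quoted for it. Both readings in this assay sit close to zero, and nothing among them points to a change beyond the scatter. The expected step is therefore a number 2 percentage points higher from compound 1 to compound 4 (within the scatter), meaning no change beyond the scatter. On this basis compound 4 is estimated at 2% in this assay, with a range from 0% to 15%.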

Compound 4, a percentage reported as inhibition, at one concentration (the size of the read-out at that concentration, not a potency): 0.5%
Beside the measured number, compound 4's estimate is 1.5 percentage points above it, within the range that was stated.
By their numbers in this assay, from the lowest: compounds 1, 3 and 4 (each within the scatter of the next).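

Among the compounds shown here, with compound 4, the exchange of hydroxy for methyl on a saturated chain carbon bound to a saturated ring carbon has its first measured step: in this assay the reading goes a number 0.5 percentage points higher from compound 1 to compound 4 (within the scatter) and so stays within the scatter, a result that no pair among the earlier compounds could give. Compound 1 gives 0% in this assay, so the step can show only that replacing hydroxymethyl with ethyl at this position brings no inhibition into view, and it cannot show whether the hydroxy contributes anything to inhibition, as there is no inhibition in compound 1 to lose. No measurement shown offers an explanation for this result.

As far as these compounds go, what stays open is whether any other group at this position, such as an amine, a carboxylic acid or a chain longer than ethyl, would lift the reading in this assay clear of the scatter. Also open is how the same exchange of hydroxy for methyl would read on a compound with clear inhibition in this assay, a case that none of the numbers shown here represents.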